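Inactive ether series: cytotoxicity limits and one untested analogue

A few compounds are considered here, and "the series" means these few. Any claim that something is new, unique, unknown or untested is made for them only; others in the source may bear on it.

compound 1 `O=c1ccoc2cc(OCc3cn(Cc4cccc(F)c4)nn3)ccc12` > 100000 nM
compound 2 `CC(C)(C)c1ccc(Cn2cc(COc3ccc4c(=O)ccoc4c3)nn2)cc1` > 100000 nM
compound 3 `C#CCOc1ccc2c(=O)ccoc2c1` > 100000 nM

In a functional assay on A549 cells (Homo sapiens) for cytotoxicity, read by MTT assay, with a stated time of 48 h (a lower number here means a stronger inhibitor, a higher number a weaker inhibitor), compound 1 gives > 100000 nM, which is a limit of the assay and not a number. Compound 2 likewise gives only a limit, > 100000 nM. Compound 3 also gives only a limit, > 100000 nM. All three values sit at the limit of > 100000 nM in this assay, at which 3 of the 3 values shown sit, so compound 1 stands with the others at the limit and no order among them can be read.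

Compound 4 `N#Cc1cccc(Cn2cc(COc3ccc4c(=O)ccoc4c3)nn2)c1` remains to be measured. It differs from compound 1 by cyano in place of fluoro on an aromatic carbon. Among the compounds with values here, no step between measured compounds is available; on this change from 3-fluorobenzyl to 3-cyanobenzyl no step beyond the scatter is expected in this assay. Compound 4 is expected to return again only a limit, estimated near 150000 nM, within 50000 nM to 500000 nM. The estimated step that the limit leaves unreadable from compound 1 to compound 4 is expected to be none beyond the scatter.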

Compound 4, half-maximal inhibitory concentration: 14300 nM
Beside the measured number, compound 4's estimate is 10-fold (1.02 log units) above it; the measured number lies below the stated range.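

In this assay, this position on the aromatic ring is not silent: cyano in place of fluoro gives an at least 6.9-fold lower number from compound 1 to compound 4 (0.84 log units; beyond the scatter). Compound 1 gives > 100000 nM, which is a limit and not a number, so the size of the step stays a bound. Compound 4 is the only compound shown that gives a number rather than this limit: the limit of > 100000 nM in this assay, at which 3 of the 4 values shown sit.

As far as these compounds go, whether other groups at this position, such as an amine, a carboxylic acid or a longer chain, would also give a number stays open. The compounds shown also offer no comparison of cyano at another place on that ring.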